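Ethoxy to dihydroxypropoxy on the isoflavone-type core

The source may report more compounds than this note shows. Statements on the series, on what has been measured and on what is new or still open speak of the compounds shown alone.

Measured compounds:
compound 1 `CCOc1ccc2c(=O)c(-c3ccc(O)cc3)coc2c1`: 100%
compound 2 `C=CCOc1ccc2c(=O)c(-c3ccc(O)cc3)coc2c1`: 100%

In a functional assay on mitochondria (Cricetulus griseus) for inhibition of Monoamine oxidase (Homo sapiens), tested at 9 uM (on this read-out lower numbers stand for a weaker effect and higher numbers for a stronger effect at the one concentration tested), compound 1 gives 100% and compound 2 gives 100%, so compound 1 stands level with compound 2 within the scatter. Among the measured compounds shown here, the only measured step, no change at the digits printed from compound 1 to compound 2 (within the scatter), shows that changing the chain on the oxygen left the read-out unchanged. Compound 3 `O=c1c(-c2ccc(O)cc2)coc2cc(OCC(O)CO)ccc12` differs from compound 1 by 1,2-dihydroxyethyl in place of methyl on a saturated chain carbon bound to an oxygen on an aromatic ring. For the measured compounds named here, that step brings in a larger, donor-bearing chain with no measured counterpart, so the expectation is weaker: compound 3 is expected to keep most of the effect, with a step of a number 12 percentage points lower from compound 1 to compound 3 (beyond the scatter), estimated at 88% (range 55% to 100%).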

Compound 3, a percentage reported as inhibition, at one concentration (the size of the read-out at that concentration, not a potency): 95.1%
Compound 3: middle estimate off by 7.1 percentage points, on the low side; the measured number falls inside the stated range.
By their numbers in this assay, from the lowest: compounds 3, 1 and 2 (each within the scatter of the next).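

Compounds 1 and 2 compare only chains made of carbon on this oxygen, whereas compound 3 adds a 1,2-dihydroxyethyl group with two hydrogen-bond donors. In this assay the change gives a number 4.9 percentage points lower from compound 1 to compound 3 (within the scatter) and, against the vinyl chain, a number 4.9 percentage points lower from compound 2 to compound 3 (within the scatter), so this position tolerates the larger, hydroxyl-bearing chain with no step beyond the scatter. Nothing available explains this tolerance.

Going by these compounds, whether an amine, a carboxylic acid or a longer chain at this position would hold the read-out remains open. A single tested concentration also leaves the potencies of these compounds unresolved.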